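Thiazol-2-yl in place of 4-fluorophenyl on the shared core

A few compounds are considered here, and "the series" means these few. Any claim that something is new, unique, unknown or untested is made for them only; others in the source may bear on it.

In a functional assay on L1210 cells (Mus musculus) for inhibition (a lower number here means a stronger inhibitor, a higher number a weaker inhibitor), compound 1 (`OC[C@H]1OC(n2cnc3c(-c4ccccn4)ncnc32)[C@H](O)[C@@H]1O`) gives 4300 nM and compound 2 (`OC[C@H]1OC(n2cnc3c(-c4ccc(F)cc4)ncnc32)[C@H](O)[C@@H]1O`) gives 4500 nM on the same core. Among the measured compounds shown here, compound 2 therefore stands within the scatter of compound 1, the only other compound measured so far.

Compound 3 (`OC[C@H]1OC(n2cnc3c(-c4nccs4)ncnc32)[C@H](O)[C@@H]1O`) carries 1,3-thiazol-2-yl in place of 4-fluorophenyl on an aromatic carbon and is otherwise unchanged.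

For the measured compounds named here, one measured step bears on this carbon: a 1.0-fold higher number from compound 1 to compound 2 (0.02 log units; within the scatter) for 4-fluorophenyl in place of pyridin-2-yl. That exchange of one aromatic group for another left the two numbers inseparable. Going by the values given here, it is thin evidence, however, and no five-membered ring has yet been measured at this carbon.

No shift beyond the scatter is therefore expected in this assay and no direction can be favoured. The expected step is a 1.1-fold lower number from compound 2 to compound 3 (0.05 log units; within the scatter) and this is the working assumption. Among the compounds with values here, for compound 3 the estimated value is 4000 nM with an expected range of 1200 nM to 13000 nM given the single step available.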

Compound 3, half-maximal inhibitory concentration: 16000 nM
For compound 3 the middle estimate is 4.0-fold (0.60 log units) below the measured one; the whole stated range lies below it.
By their numbers in this assay, from the lowest: compounds 1 and 2 (each within the scatter of the next); then compound 3.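

Among the compounds shown here, the earlier pair showed no separation between two aromatic groups at this carbon, but in this assay 1,3-thiazol-2-yl gives the first change beyond the scatter: a 3.6-fold higher number from compound 2 to compound 3 (0.55 log units; beyond the scatter), and against pyridin-2-yl, a 3.7-fold higher number from compound 1 to compound 3 (0.57 log units; beyond the scatter). For the compounds shown here, this carbon therefore does not treat every aromatic group alike: the two groups with six-membered aromatic rings remain within the scatter of each other, while the only group with a five-membered aromatic ring, which has 2 hetero atoms, gives a modestly weaker inhibitor than either. Going by these compounds alone, with only one such group, ring size cannot be separated from the ring sulfur or ring nitrogen, and no measurement at hand gives a reason for the step.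

The compounds shown leave open whether thiophen-2-yl or furan-2-yl would give a number nearer compound 3 or nearer the pair of compound 1 and compound 2, which would help separate ring size from the identity of the hetero atoms. They also leave open how this carbon responds to non-aromatic substituents such as an amine or a short alkyl chain.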